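The compounds below may be only part of what the source reports. "The series", "measured", "known", "first", "only" and "open" are said of these compounds alone.

- Compound 1 (`O=C(NCCCNc1cc(-c2cn(-c3ccccc3)nc2-c2cccc(O)c2)ccn1)Nc1ccc(F)cc1`): 1890 nM
- Compound 2 (`O=C(NCCCNc1cc(-c2cn(-c3ccccc3)nc2-c2cccc(O)c2)ccn1)Nc1cccc(C(F)(F)F)c1`): 3420 nM
- Compound 3 (`COc1cccc(-c2nn(-c3ccccc3)cc2-c2ccnc(NCCCNC(=O)Nc3ccc(F)cc3)c2)c1`): not yet measured

Within the data shown here, in a functional assay on T47D cells (Homo sapiens) for antiproliferative activity, read by sulforhodamine B assay, with a stated time of 48 h (on this read-out lower numbers stand for stronger inhibition and higher numbers for weaker inhibition), compound 1 cannot be told apart from compound 2, the only other measured compound. Compound 3 differs from compound 1 by one small change (methyl in place of hydrogen on an oxygen on an aromatic ring): methyl in place of hydrogen on an oxygen on an aromatic ring, turning hydroxy into methoxy. Among the measured compounds shown here, the sole measured step (a 1.8-fold higher number from compound 1 to compound 2 (0.26 log units; within the scatter)) lies within the scatter but concerns a different group, so no measurement tests this oxygen directly. The expected step (a 1.3-fold higher number from compound 1 to compound 3 (0.12 log units; within the scatter)) therefore stays within the scatter. For compound 3 the estimated value is 2500 nM (expected range 900 nM to 7000 nM).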

Compound 3, half-maximal inhibitory concentration: 7950 nM
Beside the measured number, compound 3's estimate is 3.2-fold (0.50 log units) below it, outside the stated range (above it).
By their numbers in this assay, from the lowest: compounds 1 and 2 (each within the scatter of the next); then compound 3.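

Turning hydroxy into methoxy gives a 4.2-fold higher number from compound 1 to compound 3 (0.62 log units; beyond the scatter) in this assay and so moves the number beyond the scatter, which the earlier step on a different group did not do. The result therefore shows that this oxygen is sensitive to the addition of a single methyl, at least in this series. No evidence given here explains the rise.

The compounds shown leave open how an amine or a fluorine in place of the hydroxy, or a longer ethoxy group on this oxygen, would read. Also open, as far as these compounds go, is whether methoxy would cost as much alongside the 3-(trifluoromethyl)phenyl group of compound 2.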